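A second fluoro on compound 2

The source may hold more compounds than are shown below. What is called first, only, known or untested is meant among the compounds shown, and "the series" means these compounds.

Compound 1 `CN(C)c1ccc(C#Cc2ccccc2)cc1` gives > 3000 nM as a limit of the assay
Compound 2 `CN(C)c1ccc(C#Cc2ccccc2F)cc1` gives 39 nM as a measured number

In a functional assay on LS174T cells (Homo sapiens) for antiproliferative activity, with a stated time of 4 days (a lower number here means a stronger inhibitor, a higher number a weaker inhibitor), compound 2 stands alone with a true number, 39 nM and no other to compare it with. Compound 3 `CN(C)c1ccc(C#Cc2cccc(F)c2F)cc1` differs from it by fluoro in place of hydrogen on an aromatic carbon with fluoro in place of hydrogen on an aromatic carbon, ortho to a fluoro group. Among the compounds with values here, the one measured step of this kind is an at least 76-fold lower number from compound 1 to compound 2 (1.88 log units; beyond the scatter) and it is large, though it starts from a limit of > 3000 nM in this assay, at which 1 of the 2 values shown sits, and so gives only a bound. Compound 2 already carries a fluoro, and a repeat of that size is not expected. The expected step is a 1.3-fold lower number from compound 2 to compound 3 (0.11 log units; within the scatter) and it is expected to stay within the scatter. Compound 3 is estimated at 30 nM with an expected range from 8 nM to 150 nM in this assay.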

Compound 3, half-maximal inhibitory concentration: 119 nM
Compound 3: middle estimate off by 4.0-fold (0.60 log units), on the low side, and the stated range covers the measured number.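

In this assay, fluoro in place of hydrogen on an aromatic carbon does not always lower the number: ortho to a fluoro group it gives a 3.1-fold higher number from compound 2 to compound 3 (0.48 log units; beyond the scatter), against the opposite direction of an at least 76-fold lower number from compound 1 to compound 2 (1.88 log units; beyond the scatter). Compound 2 thus remains the strongest of the three compounds shown. The size of the earlier step, however, can be read only as a bound: the limit of > 3000 nM in this assay, at which 1 of the 3 values shown sits.

As far as these compounds go, whether the higher number belongs to this position alone or to the pairing of two fluoro groups stays open. So does how a chloro or methoxy group would behave at this place.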